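Trading a methoxymethyl for a methoxy on the aryl ring

A few compounds are considered here, and "the series" means these few. Any claim that something is new, unique, unknown or untested is made for them only; others in the source may bear on it.

This account follows the step from compound 2 to compound 3. For the measured compounds named here, compound 2 has the structure `COCc1ccccc1C1Cc2nccn2C1` and, in a physicochemical assay for lipophilicity, at pH 7.4 (a lower number here means a more polar compound, a higher number a more lipophilic compound), compound 2 gives 1.8, the lowest of the two numbers measured so far; its nearest neighbour is compound 1, of structure `Clc1ccccc1C1Cc2nccn2C1`, which in this assay gives 2.6. Going by the values given here, the one measured step, a number 0.80 log units lower from compound 1 to compound 2 (beyond the scatter), concerns a chloro and so bears only loosely on the change at hand. Compound 3, of structure `COc1ccccc1C1Cc2nccn2C1`, differs from compound 2 by methoxy in place of methoxymethyl on an aromatic carbon. Among the compounds with values here, with no measured step of the same kind, the expectation rests on the shorter group entering; a modest rise, a number 0.40 log units higher from compound 2 to compound 3 (beyond the scatter), is expected. Compound 3 is therefore estimated at 2.2 in this assay, with a range from 1.7 to 2.7.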

Compound 3, distribution coefficient: 1.9
For compound 3 the middle estimate is 0.30 log units above the measured one; the range from low to high includes it.
By their numbers in this assay, from the lowest: compounds 2 and 3 (each within the scatter of the next); then compound 1.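

In this assay the exchange of methoxymethyl for the shorter methoxy on this aromatic carbon gives a number 0.10 log units higher from compound 2 to compound 3 (within the scatter), so this assay does not separate the two groups at this position. Methoxy in place of chloro gives a number 0.70 log units lower from compound 1 to compound 3 (beyond the scatter), and set beside a number 0.80 log units lower from compound 1 to compound 2 (beyond the scatter) this shows that chloro stands apart from both oxygen-bearing groups here, not only from methoxymethyl. Nothing available explains why the two oxygen-bearing groups read alike at this position.

The compounds shown leave open whether a longer chain such as ethoxymethyl would stay level with these two groups, and how an amine or a carboxylic acid would read in this place. They also leave open whether methoxy and methoxymethyl would still read alike on another carbon of the aromatic ring.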